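The source may report more compounds than this note shows. Statements on the series, on what has been measured and on what is new or still open speak of the compounds shown alone.

Of the compounds shown here, two sharing one core have been measured so far. Compound 1 `CC(C)c1ccc(N2C(=O)C=CC2OCC(F)(F)F)cc1` carries an isopropyl group on its aromatic ring, and in a functional assay on MDA-MB-231 cells (Homo sapiens) for inhibition (a higher number here means a weaker inhibitor, a lower number a stronger inhibitor), compound 1 gives 6640 nM. Compound 2 `O=C1C=CC(OCC(F)(F)F)N1c1cc(F)cc(F)c1` instead carries two fluorine atoms on that ring, and in this assay compound 2 gives 7840 nM. Compound 1 has the lower of the two numbers, but the gap to compound 2 lies within the scatter of repeated measurements, so the two cannot be told apart.

Compound 3 `CC(C)(C)c1ccc(N2C(=O)C=CC2OCC(F)(F)F)cc1` is the next compound to be tested. It differs from compound 1 by one change: methyl in place of hydrogen on a saturated chain carbon bound to an aromatic carbon and two saturated chain carbons. Among the measured compounds shown here, no measured pair shows what such a change does, so there is no step to lean on. The expectation is that the step from a 1.0-fold lower number from compound 1 to compound 3 (0.01 log units; within the scatter) stays within the scatter, with no clear direction. Compound 3 is therefore estimated at 6500 nM, with a range from 2500 nM to 17000 nM.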

Compound 3, half-maximal inhibitory concentration: 1860 nM
The estimate for compound 3 lay 3.5-fold (0.54 log units) above the measured number, outside the stated range (below it).
By their numbers in this assay, from the lowest: compound 3; then compounds 1 and 2 (each within the scatter of the next).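

In this assay, among the compounds shown here, going from isopropyl to tert-butyl gives a 3.6-fold lower number from compound 1 to compound 3 (0.55 log units; beyond the scatter) and is the first step that can be read. A single added methyl on this saturated chain carbon, bound to an aromatic carbon and two saturated chain carbons, is therefore enough to move the number beyond the scatter, though only modestly. No measurement shown gives a reason for this step.

Still open, on these data alone, is whether the number keeps falling when this carbon carries an ethyl group instead of the added methyl, or whether a hydroxyl group there would do the same. As far as these compounds go, this change is also seen only once, on a single version of the shared core, so it remains unknown whether the step would repeat on other versions.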